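Working notes: the aryl group on the nitrogen, compound 3

The source may report more compounds than this note shows. Statements on the series, on what has been measured and on what is new or still open speak of the compounds shown alone.

Compound 1 `CN1CCN(c2ccc(Nc3ncc(Cl)c(NCc4ccc(F)cc4)n3)nc2)CC1`: > 100000 nM, a limit of the assay
Compound 2 `Cc1ccc(Nc2nc(Nc3ccc(N4CCN(C)CC4)cn3)ncc2Cl)cc1`: 30900 nM

For the measured compounds named here, in a functional assay on Jurkat cells (Homo sapiens) for inhibition, read by CCK-8 assay, with a stated time of 48 h (on this read-out lower numbers stand for stronger inhibition of growth and higher numbers for weaker inhibition of growth), compound 2 gives 30900 nM, the only actual number so far. Compound 1 is recorded only as a limit, > 100000 nM; this is the limit of > 100000 nM in this assay, at which 1 of the 2 values shown sits.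

Compound 3 `CC(C)c1cccc(Nc2nc(Nc3ccc(N4CCN(C)CC4)cn3)ncc2Cl)c1` changes one place in compound 2: 3-isopropylphenyl in place of 4-methylphenyl on a nitrogen on an aromatic ring. In words, this is 3-isopropylphenyl in place of 4-methylphenyl on a nitrogen on an aromatic ring.

Going by the values given here, one measured step bears on this place, an at least 3.2-fold lower number from compound 1 to compound 2 (0.51 log units; beyond the scatter). It shows that a swap on this nitrogen can shift the number in this assay, but its size is bounded on one side only. It also involves a different pair of groups, so it does not fix the size or direction of the next step. No step beyond the scatter is therefore expected, with a slight lean towards a lower number. The estimate is a 1.5-fold lower number from compound 2 to compound 3 (0.19 log units; within the scatter). For compound 3 the expected value is 20000 nM, with an estimated range of 6000 nM to 70000 nM.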

Compound 3, concentration for 50% growth inhibition: 12300 nM
Estimate against measurement, compound 3: 1.6-fold (0.21 log units) above, within the range that was stated.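

In this assay, the swap on this nitrogen now gives a step between two actual numbers rather than against a limit: a 2.5-fold lower number from compound 2 to compound 3 (0.40 log units; beyond the scatter). This shows that the number responds to a change within the phenyl series itself, with no benzyl group involved, and that the step lies beyond the scatter although both groups are carbon-only aromatic groups with no hydrogen-bond donors or acceptors. The wider step is an at least 8.1-fold lower number from compound 1 to compound 3 (0.91 log units; beyond the scatter), and it is open on one side, since one end of it is a limit of the assay: the limit of > 100000 nM in this assay, at which 1 of the 3 values shown sits.

The change from 4-methylphenyl to 3-isopropylphenyl alters both the substituent and its place on the ring, and the compounds shown cannot tell these two parts apart; 3-methylphenyl and 4-isopropylphenyl on the same nitrogen would separate them. As far as these compounds go, how a carboxylic acid or an amine on this phenyl ring would read, and whether any group here reaches a much lower number, also stays open.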